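Swapping bromo for trifluoromethyl in compound 2

The source may report more compounds than this note shows. Statements on the series, on what has been measured and on what is new or still open speak of the compounds shown alone.

Compound 1 `O=[N+]([O-])c1ccc(S(=O)(=O)n2c(-c3cn(-c4ccccc4)nc3-c3ccc(F)cc3)nc3ccccc32)cc1` gives 1170 nM
Compound 2 `O=S(=O)(c1ccc(Br)cc1)n1c(-c2cn(-c3ccccc3)nc2-c2ccc(F)cc2)nc2ccccc21` gives 2040 nM

In a functional assay on HeLa cells (Homo sapiens) for antiproliferative activity, read by MTT assay, with a stated time of 24 h (a higher number here means a weaker inhibitor, a lower number a stronger inhibitor), compound 2 stands at 2040 nM and so sits within the scatter of compound 1 (1170 nM). Compound 3 `O=S(=O)(c1ccc(C(F)(F)F)cc1)n1c(-c2cn(-c3ccccc3)nc2-c2ccc(F)cc2)nc2ccccc21` carries trifluoromethyl in place of bromo on an aromatic carbon. For the measured compounds named here, the one measured step that bears on this change put bromo in place of nitro on an aromatic carbon (a 1.7-fold higher number from compound 1 to compound 2 (0.24 log units; within the scatter)) and stayed within the scatter. No step beyond the scatter is therefore expected in this assay, and no clear direction can be called. The estimated step is small (a 1.4-fold lower number from compound 2 to compound 3 (0.13 log units; within the scatter)). For compound 3 the expected value is 1500 nM with an estimated range from 700 nM to 3200 nM in repeat measurements.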

Compound 3, half-maximal inhibitory concentration: 1430 nM
The estimate for compound 3 lay 1.0-fold (0.02 log units) above the measured number; the measured number falls inside the stated range.
By their numbers in this assay, from the lowest: compounds 1, 3 and 2 (each within the scatter of the next).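

Read in this assay this position shows a 1.4-fold lower number from compound 2 to compound 3 (0.15 log units; within the scatter) for trifluoromethyl in place of bromo and a 1.2-fold higher number from compound 1 to compound 3 (0.09 log units; within the scatter) for trifluoromethyl in place of nitro. The three groups on this aromatic carbon, para to a large group, therefore stand within the scatter of one another, although trifluoromethyl has more heavy atoms than bromo. Nothing available here accounts for this result. Going by these compounds, whether an amine or a carboxylic acid on the same carbon would stay within that scatter remains open. So does the outcome of moving trifluoromethyl to another carbon of that ring.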